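Phenyl for Methyl on the Carbonyl: Expected Growth Inhibition

The compounds below may be only part of what the source reports. "The series", "measured", "known", "first", "only" and "open" are said of these compounds alone.

Three compounds have measured values in a functional assay on HCT-116 cells (Homo sapiens) for inhibition, read by sulforhodamine B assay, with a stated time of 48 h; on this read-out higher numbers stand for weaker inhibition of growth and lower numbers for stronger inhibition of growth. Compound 1 `COc1ccc(-c2[nH]c3ccccc3c2/C=C(\C#N)S(=O)(=O)c2ccccc2)cc1` gives 399 nM, compound 2 `COc1ccc(-c2[nH]c3ccc(OC)cc3c2/C=C(\C#N)S(=O)(=O)c2ccccc2)cc1` gives 539 nM, and compound 3 `CC(=O)/C(=C\c1c(-c2ccccc2)[nH]c2ccccc12)S(=O)(=O)c1ccccc1` gives 754 nM. Compound 3 has the highest number of the three, yet its gaps to compound 1 and compound 2 both lie within the scatter, so no ranking among them can be read. Going by the values given here, the only single-point step, a 1.4-fold higher number from compound 1 to compound 2 (0.13 log units; within the scatter), also stays within the scatter. Compound 4 `O=C(/C(=C\c1c(-c2ccccc2)[nH]c2ccccc12)S(=O)(=O)c1ccccc1)c1ccccc1` differs from compound 3 by phenyl in place of methyl on a carbonyl carbon, that is, acetyl to benzoyl. Among the compounds with values here, no measured step touches this carbonyl group, so the only guide is the flat picture among the three measured compounds. The step of a 1.1-fold lower number from compound 3 to compound 4 (0.03 log units; within the scatter) is expected to be none beyond the scatter. Compound 4 is therefore estimated at 700 nM in this assay, within 250 nM to 2000 nM.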

Compound 4, concentration for 50% growth inhibition: 4900 nM
For compound 4 the middle estimate is 7.0-fold (0.85 log units) below the measured one, and the stated range ends below it.
By their numbers in this assay, from the lowest: compounds 1, 2 and 3 (each within the scatter of the next); then compound 4.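

In this assay, going by these compounds alone, the carbonyl carbon turns out to be a position where a change can be read: phenyl in place of methyl gives a 6.5-fold higher number from compound 3 to compound 4 (0.81 log units; beyond the scatter) and is the first step here beyond the scatter. Growth inhibition is therefore weaker with benzoyl than with acetyl, although the step is modest and rests on a single pair. Nothing measured here bears on the reason for this step. Going by these compounds, whether an ethyl group or an amine on the carbonyl carbon would stay close to compound 3 or move toward compound 4 remains open.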